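The compounds below may be only part of what the source reports. "The series", "measured", "known", "first", "only" and "open" are said of these compounds alone.

Working notes on the benzyloxy-substituted pyrazole series. Compound 1 `Cc1cc(C(=O)O)nn1Cc1cc(Br)ccc1OCc1ccccc1` carries a free carboxylic acid on the core, and in a physicochemical assay for lipophilicity, at pH 7.4 (on this read-out lower numbers stand for lower lipophilicity and higher numbers for higher lipophilicity), compound 1 gives 1.2. Compound 2 `Cc1cc(C(=O)NCc2ccccn2)nn1Cc1cc(Cl)ccc1OCc1ccccc1` replaces that acid with an amide to a pyridinylmethyl group and swaps the bromo for a chloro substituent. In this assay compound 2 reaches only a limit of the assay, > 3.7, so no number is available for it; this is where the limit of > 3.7 in this assay, at which 1 of the 2 values shown sits, sits.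

Compound 3 `Cc1cc(NC(=O)OCC(C)C)nn1Cc1cc(Cl)ccc1OCc1ccccc1` is not yet measured. It differs from compound 2 by (isobutoxycarbonyl)amino in place of ((pyridin-2-yl)methyl)carbamoyl on an aromatic carbon. With no numerical value for compound 2, the step can only be expected rather than computed. For compound 3 the expected step in this assay is a step that the limit leaves unreadable from compound 2 to compound 3, from the limit upward by an amount not clearly beyond the scatter. Compound 3 is therefore estimated at 4.2, with a range from 3.6 to 4.8, and it may again come back only as a limit.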

Compound 3, distribution coefficient: 3.3
Beside the measured number, compound 3's estimate is 0.90 log units above it, and the stated range ends above it.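

In this assay, (isobutoxycarbonyl)amino in place of ((pyridin-2-yl)methyl)carbamoyl on this aromatic carbon of the shared core gives a number at least 0.40 log units lower from compound 2 to compound 3 (beyond the scatter). Compound 3 gives 3.3, a number rather than a limit, so a group with no ring at this position falls inside the range that this read-out can resolve. The true size of the step stays open-ended, as it is anchored on a limit for compound 2, not a number: the limit of > 3.7 in this assay, at which 1 of the 3 values shown sits.

On these data alone, it remains open which part of the exchanged group accounts for the step, and how a plain amine or a longer chain on this aromatic carbon would read in this assay. The compounds shown also contain no pair that differs only in the bromo or chloro substituent.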